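The source may hold more compounds than are shown below. What is called first, only, known or untested is meant among the compounds shown, and "the series" means these compounds.

Measured compounds in an assay on cells for inhibition of HSP60/HSP10 (Homo sapiens), with a stated time of 60 min; on this read-out lower numbers stand for stronger inhibition and higher numbers for weaker inhibition:

Compound 1 `COc1cccc(S(=O)(=O)Nc2ccc3oc(-c4ccccc4)nc3c2)c1` gives > 100000 nM, a limit of the assay.
Compound 2 `COc1ccc(S(=O)(=O)Nc2ccc3oc(-c4ccccc4)nc3c2)cc1` gives > 100000 nM, a limit of the assay.
Compound 3 `COc1ccc(S(=O)(=O)Nc2ccc(-c3nc4ccccc4o3)cc2)cc1` gives > 100000 nM, a limit of the assay.

All three measured values sit at the limit of > 100000 nM in this assay, at which 3 of the 3 values shown sit, so no number is known for any of them. The change from compound 2 to compound 1 is 3-methoxyphenyl in place of 4-methoxyphenyl on a sulfonyl sulfur; its step, a step that the two limits leave unreadable from compound 2 to compound 1, cannot be read because both ends are limits. The difference between the core of compound 2 and the core of compound 3 is not broken down here.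

Compound 4 `COc1cccc(S(=O)(=O)Nc2ccc(-c3nc4ccccc4o3)cc2)c1` is not yet measured. It differs from compound 3 by 3-methoxyphenyl in place of 4-methoxyphenyl on a sulfonyl sulfur, the same change as from compound 2 to compound 1, with the same surroundings at the place of change. Going by the values given here, since the only measured instance of this change joins two limits, and compound 3 itself is a limit, the expected step from compound 3 to compound 4 is a step that the limit leaves unreadable from compound 3 to compound 4, again unreadable in practice. Compound 4 is therefore expected to give 150000 nM in this assay, most likely reported as a limit, with an estimated range from 50000 nM to 500000 nM.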

Compound 4, half-maximal inhibitory concentration: 80000 nM
Compound 4: middle estimate off by 1.9-fold (0.27 log units), on the high side; low and high end bracket the measured number.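

In this assay, 3-methoxyphenyl in place of 4-methoxyphenyl on a sulfonyl sulfur gives an at least 1.2-fold lower number from compound 3 to compound 4 (0.09 log units; that floor lies within the scatter), so on the core of compound 3 this floor alone does not establish a real change, although the true size could be larger since one end is a limit. On the core of compound 1 the same change joins two limits and its step cannot be read, so there are not two sizes to compare, and the series shows neither that the change carries from one core to the other nor that it fails to. Most of the series remains at the limit of the read-out: the limit of > 100000 nM in this assay, at which 3 of the 4 values shown sit.

Still open, as far as these compounds go, is whether any compound can reach a number well away from that limit, since all four compounds carry a methoxyphenyl on the sulfonyl sulfur. An amine or a carboxylic acid in place of the methoxy group would test whether the read-out responds to that part of the molecule on either core.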